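The source may report more compounds than this note shows. Statements on the series, on what has been measured and on what is new or still open speak of the compounds shown alone.

For the measured compounds named here, in a functional assay on HCT-116 cells (Homo sapiens) for cytotoxicity, read by MTT assay, with a stated time of 72 h (a lower number here means a stronger inhibitor, a higher number a weaker inhibitor), compound 1 `O=C1c2c[n+]([O-])c3ccccc3c2C(=O)c2c1c1ccccc1n2Cc1cn([C@H]2O[C@H](CO)[C@@H](O)[C@H]2O)nn1` gives 710 nM, the highest of the three numbers measured so far. Compound 2 `CN1CCN(CCCCn2c3c(c4ccccc42)C(=O)c2c[n+]([O-])c4ccccc4c2C3=O)CC1` gives 10 nM in this assay, and compound 3 `O=C1c2c[n+]([O-])c3ccccc3c2C(=O)c2c1c1ccccc1n2CCCCN1CCCCC1` gives 200 nM. Going by the values given here, the one measured step, a 20-fold higher number from compound 2 to compound 3 (1.30 log units; beyond the scatter), concerns the amine at the end of the saturated chain on the shared core and does not touch the sugar, so no measured step bears directly on the change to compound 4 `O=C1c2c[n+]([O-])c3ccccc3c2C(=O)c2c1c1ccccc1n2Cc1cn([C@@H]2O[C@H](CO)[C@@H](O)[C@H](O)[C@H]2O)nn1`, which is 3,4,5-trihydroxy-6-(hydroxymethyl)oxan-2-yl in place of 3,4-dihydroxy-5-(hydroxymethyl)oxolan-2-yl on an aromatic nitrogen. Among the compounds with values here, with no comparable step in hand, the change expected in this assay is none beyond the scatter, with the uncertainty widened on both sides. Compound 4 is therefore estimated at 800 nM, within a range of 300 nM to 2200 nM. This expectation amounts to a step of a 1.1-fold higher number from compound 1 to compound 4 (0.05 log units; within the scatter).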

Compound 4, half-maximal inhibitory concentration: 130 nM
The estimate for compound 4 lay 6.2-fold (0.79 log units) above the measured number; the measured number lies below the stated range.
By their numbers in this assay, from the lowest: compound 2; then compounds 4 and 3 (each within the scatter of the next); then compound 1.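

In this assay, for the compounds shown here, the earlier compounds showed only that the amine at the end of the chain matters, whereas a 5.5-fold lower number from compound 1 to compound 4 (0.74 log units; beyond the scatter) shows that the group on the aromatic nitrogen of the five-membered ring also moves the number beyond the scatter. The two groups differ at once in ring size, hydrogen-bond donors and acceptors, and stereocentres, so this step cannot assign the change to any one of these. Nothing available here accounts for the step. Going by these compounds, whether an open-chain diol or a simple amine in this place would give a similar number remains open.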